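Extending a Ketone Side Chain: Effect on Fly Cell Toxicity

The source may report more compounds than this note shows. Statements on the series, on what has been measured and on what is new or still open speak of the compounds shown alone.

Four aryl ketones are compared here, all with a saturated chain on the carbonyl carbon. Compound 1 `CCCCCCC(=O)c1c(OC)c(Cl)c(OC)c(Cl)c1OC` and compound 2 `CCCCCC(=O)c1c(OC)c(Cl)c(OC)c(Cl)c1OC` share one core; compound 3 `CCCCCCCC(=O)c1c(O)c(Cl)c(O)c(Cl)c1O` and compound 4 `CCCCCCCCC(=O)c1c(O)c(Cl)c(O)c(Cl)c1O` share another. The difference between the two cores is not broken down here.

In an ADME assay on the whole organism (strain S2) for cytotoxicity, with Drosophila as the target, read by WST assay (on this read-out higher numbers stand for lower toxicity in this test and lower numbers for higher toxicity in this test), compound 2 gives 148000 nM. Compound 1 gives 140000 nM. The two differ only by methyl in place of hydrogen on a saturated chain carbon, five bonds along the chain from a carbonyl carbon, and the resulting step, a 1.1-fold lower number from compound 2 to compound 1 (0.02 log units; within the scatter), leaves the toxicity essentially unchanged. In this assay compound 3 gives 88500 nM; its distance to compound 1 and to compound 2 lies within the scatter of repeated measurements, so no ordering among the three can be claimed.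

Compound 4 has not been measured. It differs from compound 3 by methyl in place of hydrogen on a saturated chain carbon, seven bonds along the chain from a carbonyl carbon. Among the measured compounds shown here, this is the same kind of change as the one between compound 2 and compound 1, not the same change: there the methyl entered five bonds along the chain from the carbonyl carbon, here it enters seven bonds along the chain from the carbonyl carbon. The expected step is a 1.1-fold lower number from compound 3 to compound 4 (0.04 log units; within the scatter), because the same kind of change gave a 1.1-fold lower number from compound 2 to compound 1 (0.02 log units; within the scatter). Compound 4 is therefore expected to give 80000 nM in this assay, with a likely range from 40000 nM to 160000 nM.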

Compound 4, half-maximal cytotoxic concentration: 82800 nM
For compound 4 the middle estimate is 1.0-fold (0.01 log units) below the measured one; the range from low to high includes it.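

In this assay, methyl in place of hydrogen on a saturated chain carbon, seven bonds along the chain from a carbonyl carbon, gives a 1.1-fold lower number from compound 3 to compound 4 (0.03 log units; within the scatter), so on this core the added carbon leaves the toxicity reading essentially unchanged. Set beside the earlier step on the other core, the change behaves alike on both: the same change on two cores in this assay, a 1.1-fold lower number (0.02 log units; within the scatter) from compound 2 to compound 1 and a 1.1-fold lower number (0.03 log units; within the scatter) from compound 3 to compound 4, 1.0-fold (0.00 log units) apart, within the scatter of two such steps

This agreement shows only that a single added methyl at the end of the chain produced no readable shift on either core; it does not show that chain length is without effect in general, and it rests on two steps that are of the same kind but sit at different places, five bonds and seven bonds along the chain from the carbonyl carbon.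

The compounds shown leave open whether a much longer chain, or a chain ending in an amine or a carboxylic acid, would move the number beyond the scatter. They also leave open how the two cores compare on their own, as no pair shown differs in the core alone.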